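Replacing the benzyl group of compound 2

A few compounds are considered here, and "the series" means these few. Any claim that something is new, unique, unknown or untested is made for them only; others in the source may bear on it.

Compound 1 `COc1ncc(-c2ccc3ncc(NCc4ccc(C(F)(F)F)cc4)c(OC)c3c2)cc1NS(=O)(=O)c1ccc(F)cc1F`: 3220 nM
Compound 2 `COc1ncc(-c2ccc3ncc(NCc4ccccc4)c(OC)c3c2)cc1NS(=O)(=O)c1ccc(F)cc1F`: 16800 nM

Both numbers come from a functional assay on HCT-116 cells (Homo sapiens) for antiproliferative activity, read by sulforhodamine B assay, with a stated time of 72 h; a higher number here means a weaker inhibitor, a lower number a stronger inhibitor. Of the pair, compound 2 has the higher number at 16800 nM, which makes it the weaker inhibitor. The next compound is compound 3 `COc1ncc(-c2ccc3ncc(NC(=O)C4CCCCC4)c(OC)c3c2)cc1NS(=O)(=O)c1ccc(F)cc1F`, with cyclohexylcarbonyl in place of benzyl on a nitrogen on an aromatic ring. Put another way, benzylamino becomes (cyclohexylcarbonyl)amino.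

Among the compounds with values here, only one measured step bears on this change, and only indirectly: a 5.2-fold higher number from compound 1 to compound 2 (0.72 log units; beyond the scatter). This modest step, from hydrogen in place of trifluoromethyl on an aromatic carbon, shows that altering the benzyl group alone can shift the number beyond the scatter. Within the data shown here, compound 3 loses that group entirely, and no measured compound carries cyclohexylcarbonyl, so the data do not settle the direction. Since compound 1 reaches 3220 nM with a different group on that nitrogen, a small fall is expected rather than a rise. The expected change is a 2.4-fold lower number from compound 2 to compound 3 (0.38 log units; beyond the scatter), with wide uncertainty. For compound 3 the estimate is 7000 nM, with an expected range from 2000 nM to 25000 nM.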

Compound 3, half-maximal inhibitory concentration: 4610 nM
Beside the measured number, compound 3's estimate is 1.5-fold (0.18 log units) above it; the measured number falls inside the stated range.
By their numbers in this assay, from the lowest: compounds 1 and 3 (each within the scatter of the next); then compound 2.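

Measured in this assay the nitrogen on the aromatic ring accepts a much larger change than a substituent on the benzyl ring: cyclohexylcarbonyl in place of benzyl swaps the aromatic ring for a non-aromatic one, adds a carbonyl, and still gives a gain in potency (a 3.6-fold lower number from compound 2 to compound 3 (0.56 log units; beyond the scatter)). An aromatic ring in this group is therefore not needed to reach this level of activity, at least among these compounds. The comparison with the trifluoromethyl-bearing compound (a 1.4-fold higher number from compound 1 to compound 3 (0.16 log units; within the scatter)) shows that cyclohexylcarbonyl and 4-(trifluoromethyl)benzyl cannot be told apart here, even though they are very different groups, and nothing available explains the shift or this match.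

As far as these compounds go, the ring and the carbonyl change together in one step, so their separate contributions remain open, and a cyclohexylmethyl group or a benzoyl group on the same nitrogen would pull them apart. Also open, from the compounds shown here alone, is how much of the cyclohexane ring matters, which a smaller acyl group such as acetyl could test.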